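Adding a fluorine to a weak benzamide thiazole

This account rests on a few compounds, and the source may have more. Where it says the series, first, only, none or still open, it means among the compounds named here.

Measured so far:
- compound 1 `CCOC(=O)c1sc(-c2cccc(NC(=O)c3ccc(C(F)(F)F)cc3)c2)nc1Nc1ccc(N2CCN(C)CC2)cc1` — "not determined" (no result reported)
- compound 2 `CCOC(=O)c1sc(-c2cccc(NC(=O)c3ccc(C(C)(C)C)cc3)c2)nc1Nc1ccc(N2CCN(C)CC2)cc1` — "not determined" (no result reported)
- compound 3 `CCOC(=O)c1sc(-c2cccc(NC(=O)c3ccccc3)c2)nc1Nc1ccc(N2CCN(C)CC2)cc1` — 24800 nM

The three compounds share one core and differ only in the group attached to the amide at the outer end. In a functional assay on Ramos cells (Homo sapiens) for antiproliferative activity, read by CCK-8 assay, with a stated time of 72 h (a lower number here means a stronger inhibitor, a higher number a weaker inhibitor), compound 3 gives 24800 nM, a weak result, and since compound 1 and compound 2 carry no number, compound 3 is the only point of reference here. Within the data shown here, no step between measured compounds can be drawn from this set.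

Compound 4 `CCOC(=O)c1sc(-c2cccc(NC(=O)c3cccc(F)c3)c2)nc1Nc1ccc(N2CCN(C)CC2)cc1` keeps everything of compound 3 and changes one place only: fluoro in place of hydrogen on an aromatic carbon. A single fluorine added to the outer aromatic ring is among the smallest changes a chemist can make. Among the measured compounds shown here, with no measured step to lean on, the expectation for this assay is a step close to nothing, no larger than the usual scatter, in either direction. The step expected in this assay is a 1.2-fold lower number from compound 3 to compound 4 (0.09 log units; within the scatter). Compound 4 is therefore estimated at 20000 nM, with a range from 7000 nM to 60000 nM.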

Compound 4, half-maximal inhibitory concentration: 12800 nM
Estimate against measurement, compound 4: 1.6-fold (0.19 log units) above, within the range that was stated.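

In this assay, among these compounds, fluoro in place of hydrogen on the outer ring gives a 1.9-fold lower number from compound 3 to compound 4 (0.29 log units; within the scatter), the first measured step at this place on the molecule. A step of this size cannot be told apart from the differences seen between repeated measurements, so this one-atom swap shows no clear effect on the activity of the benzamide, and compound 3 and compound 4 remain in the same weak range. Nothing shown here offers any measured explanation for this small step.

Steps involving compound 1 or compound 2 cannot be read, since neither compound has a number. From the compounds shown here alone, it remains open whether a chloro, an amine or a carboxylic acid in this same place would give a step beyond the usual scatter of the assay.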